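From Cyclohexyl to Ethyl Ester: Expected Cytotoxicity

This account rests on a few compounds, and the source may have more. Where it says the series, first, only, none or still open, it means among the compounds named here.

Measured compounds:
compound 1 `Nc1ncnc2c1ncn2CC(O)C(=O)OC1CCCCC1` — compound 1 gives 100 ug/mL
compound 2 `CCCCCOC(=O)C(O)Cn1cnc2c(N)ncnc21` — compound 2 gives only a limit of the assay, > 400 ug/mL
compound 3 `Nc1ncnc2c1ncn2CC(O)C(=O)OCc1ccco1` — compound 3 gives 40 ug/mL

Three esters sharing one core were tested in a functional assay on HeLa cells (Homo sapiens) for cytotoxicity; on this read-out higher numbers stand for lower toxicity in this test and lower numbers for higher toxicity in this test. Among the numbers shown, compound 1 stands highest of the two; compound 3 comes nearest, and the step of a 2.5-fold lower number from compound 1 to compound 3 (0.40 log units; beyond the scatter) was modest. The third value is a limit rather than a number (the limit of > 400 ug/mL in this assay, at which 1 of the 3 values shown sits).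

Compound 4 `CCOC(=O)C(O)Cn1cnc2c(N)ncnc21` has not yet been measured in this assay. It differs from compound 1 in one place: ethyl in place of cyclohexyl on an oxygen next to a carbonyl group. For the measured compounds named here, two measured steps bear on this change. The first is an at least 4.0-fold higher number from compound 1 to compound 2 (0.60 log units; beyond the scatter), where pentyl replaced cyclohexyl on the same oxygen. The second is a 2.5-fold lower number from compound 1 to compound 3 (0.40 log units; beyond the scatter), which went the other way. The pentyl step is the closer guide: ethyl, like pentyl, is a chain on that oxygen. Compound 4 is therefore expected to show a higher number than compound 1, with the step estimated as a 4.0-fold higher number from compound 1 to compound 4 (0.60 log units; beyond the scatter). The estimate for compound 4 is 400 ug/mL, with a range from 100 ug/mL to 1600 ug/mL, and the assay may again report only a limit.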

Compound 4, minimum cytotoxic concentration: > 400 ug/mL
Compound 4: only a limit was reported; the forecaster's own chance of this, stated with the estimate: 60%; the middle value sits exactly at the limit.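

In this assay compound 4 gives only a limit of the assay, > 400 ug/mL. Ethyl in place of cyclohexyl on this oxygen gives an at least 4.0-fold higher number from compound 1 to compound 4 (0.60 log units; beyond the scatter), and methyl in place of furan-2-yl gives an at least 10-fold higher number from compound 3 to compound 4 (1.00 log units; beyond the scatter), so a chain much shorter than pentyl also reaches the limit, and among these four esters the two with a plain chain stand at the limit while the two carrying a ring give numbers, with no compound shown going against this. The step between compound 2 and compound 4 cannot be read, so these results give no order between ethyl and pentyl, as both esters stand at the same limit: the limit of > 400 ug/mL in this assay, at which 2 of the 4 values shown sit.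

From the compounds shown here alone, how far the two chain esters lie beyond the limit stays open, and so does any difference between them. Going by these compounds, it also remains open whether a chain longer than pentyl, a branched chain such as isopropyl, or an ester chain ending in an amine would bring the read-out back to a number within the range of this assay.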